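Half-life after capping the 4-hydroxycyclohexyl group

The source may hold more compounds than are shown below. What is called first, only, known or untested is meant among the compounds shown, and "the series" means these compounds.

Measured so far in an in vitro ADME assay on microsomes (Homo sapiens) for metabolic stability; a higher number here means that the compound lasts longer, a lower number that the compound disappears faster:
- compound 1 (`O=C(Nc1ccncc1)Nc1ccc(-c2nc(N3CC4CCC(C3)O4)c3cnn(C4CCC5(CC4)OCCO5)c3n2)cc1`) gives 0.217 h
- compound 2 (`CNC(=O)Nc1ccc(-c2nc(N3CC4CCC(C3)O4)c3cnn([C@H]4CC[C@@H](O)CC4)c3n2)cc1`) gives > 0.5 h (a limit, not a number)
- compound 3 (`O=C(Nc1ccc(-c2nc(N3CC4CCC(C3)O4)c3cnn(C4CCC5(CC4)OCCO5)c3n2)cc1)NC1CC1`) gives 0.15 h

As far as these compounds go, compound 2 stands at the limit of > 0.5 h in this assay, at which 1 of the 3 values shown sits (a limit of the assay, so its true distance from the other compounds is unknown). The step under study leads to compound 4 (`CNC(=O)Nc1ccc(-c2nc(N3CC4CCC(C3)O4)c3cnn([C@H]4CC[C@H](OC)CC4)c3n2)cc1`) and is 4-methoxycyclohexyl in place of 4-hydroxycyclohexyl on an aromatic nitrogen (in words, 4-methoxycyclohexyl in place of 4-hydroxycyclohexyl on an aromatic nitrogen). Among the compounds with values here, no measured step changes the group at this place. Within the data shown here, the only measured step is a 1.4-fold lower number from compound 1 to compound 3 (0.16 log units; within the scatter) (cyclopropyl in place of pyridin-4-yl on an amide-type nitrogen). It lies elsewhere on the molecule and bears on this change only weakly, as a sign of how far values in this assay can stay together across a substitution. A modest move towards a lower number is expected, though with little support, and a reading that is again only a limit remains possible. The expected size is an at least 1.2-fold lower number from compound 2 to compound 4 (0.09 log units; that floor lies within the scatter) (an estimate resting on the structural change alone). For compound 4 the estimated half-life is 0.4 h (expected range 0.2 h to 0.8 h).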

Compound 4, half-life: 0.25 h
For compound 4 the middle estimate is 1.6-fold (0.20 log units) above the measured one, and the stated range covers the measured number.
By their numbers in this assay, from the lowest: compounds 3, 1 and 4 (each within the scatter of the next). At a limit, above all of these: compound 2.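

Working notes on the group on the aromatic nitrogen: 4-methoxycyclohexyl in place of 4-hydroxycyclohexyl gives the first measured step at this place in this assay, and the step reads as an at least 2.0-fold lower number from compound 2 to compound 4 (0.30 log units; that floor lies within the scatter). Going from 1 hydrogen-bond donor to 0 in this group, with the rest of the molecule unchanged, brings no gain in half-life in this pair, so the free hydroxyl is not needed for a reading at the limit to be lost or kept on this evidence alone. As far as these compounds go, the reading for compound 2 of > 0.5 h is a limit and not a number, so the step has only a floor and its true size is unknown: the limit of > 0.5 h in this assay, at which 1 of the 4 values shown sits.

Still open, from the compounds shown here alone, is how far the half-life of compound 2 actually lies from that of compound 4, and so whether the change exceeds the usual scatter at all. Also open, going by these compounds, is how an amine, a carboxylic acid or an ethoxy group in place of the methoxy group on the cyclohexyl ring would read in this assay, with the rest of the molecule held as in compound 4.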